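Swapping Chloro for Bromo in Compound 3

The compounds below may be only part of what the source reports. "The series", "measured", "known", "first", "only" and "open" are said of these compounds alone.

In a functional assay on A549 cells (Homo sapiens) for antiproliferative activity, read by MTT assay, with a stated time of 48 h (a higher number here means a weaker inhibitor, a lower number a stronger inhibitor), compound 1 `Cc1ccc(C(=O)/C=C/c2cc(Cl)cc(Cl)c2Oc2c([N+](=O)[O-])cc(C(F)(F)F)cc2[N+](=O)[O-])cc1` gives 10.1 ug/mL and compound 2 `O=C(/C=C/c1cc(Cl)cc(Cl)c1Oc1c([N+](=O)[O-])cc(C(F)(F)F)cc1[N+](=O)[O-])c1ccc(F)cc1` gives 29.4 ug/mL while compound 3 `O=C(/C=C/c1cc(Cl)cc(Cl)c1Oc1c([N+](=O)[O-])cc(C(F)(F)F)cc1[N+](=O)[O-])c1ccc(Cl)cc1` gives 17.2 ug/mL and so sits within the scatter of both others. Compound 4 `O=C(/C=C/c1cc(Cl)cc(Cl)c1Oc1c([N+](=O)[O-])cc(C(F)(F)F)cc1[N+](=O)[O-])c1ccc(Br)cc1` has bromo in place of chloro on an aromatic carbon, para to a large group bromo in place of chloro on an aromatic carbon and is not yet measured. Among the compounds with values here, the closest precedent, chloro in place of fluoro, is a 1.7-fold lower number from compound 2 to compound 3 (0.23 log units; within the scatter) and stays within the scatter. So does a 1.7-fold higher number from compound 1 to compound 3 (0.23 log units; within the scatter) while only a 2.9-fold higher number from compound 1 to compound 2 (0.46 log units; beyond the scatter) goes beyond it. No shift beyond the scatter is therefore expected in this assay here. The expected step is a 1.1-fold lower number from compound 3 to compound 4 (0.03 log units; within the scatter) on this estimate. Compound 4 is expected to give about 16 ug/mL with an estimated range from 8 ug/mL to 31 ug/mL when tested.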

Compound 4, half-maximal inhibitory concentration: 14.5 ug/mL
For compound 4 the middle estimate is 1.1-fold (0.04 log units) above the measured one; low and high end bracket the measured number.
By their numbers in this assay, from the lowest: compounds 1, 4, 3 and 2 (each within the scatter of the next, the first and the last beyond it).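

In this assay, this place on the 4-bromophenyl ring now has a third halogen, and bromo in place of chloro gives a 1.2-fold lower number from compound 3 to compound 4 (0.07 log units; within the scatter). Bromo in place of fluoro gives a 2.0-fold lower number from compound 2 to compound 4 (0.31 log units; beyond the scatter) and bromo in place of methyl gives a 1.4-fold higher number from compound 1 to compound 4 (0.16 log units; within the scatter), so fluoro now has steps beyond the scatter to both methyl and bromo, although its step to chloro stays within it. On these data alone, whether an amine, a carboxylic acid or a methoxy group at this place would give a similar number remains open. Nothing available here gives a reason for these steps.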